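The source may hold more compounds than are shown below. What is called first, only, known or untested is meant among the compounds shown, and "the series" means these compounds.

Measured so far in a functional assay, read by Griess assay, with a stated time of 2.5 h; on this read-out higher numbers stand for weaker inhibition and lower numbers for stronger inhibition:
- compound 1 `COc1cc(OC)c(OC)cc1/C=C/C(=O)c1ccc(O)cc1O`: 2.76 ug/mL
- compound 2 `COc1cc(OC)c(OC)cc1/C=C/C(=O)c1ccc(F)cc1`: 1.96 ug/mL
- compound 3 `COc1cc(C(=O)/C=C/c2cc(OC)c(OC)cc2OC)ccc1O`: 2.46 ug/mL

Compound 3, at 2.46 ug/mL, lies within the scatter of both compound 1 and compound 2, so these three numbers do not separate the compounds.

The next compound is compound 4 `COc1cc(OC)c(OC)cc1/C=C/C(=O)c1ccc(O)cc1`, which carries hydrogen in place of methoxy on an aromatic carbon of compound 3, ortho to a hydroxy group: hydrogen in place of methoxy on an aromatic carbon.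

Within the data shown here, no measured pair isolates this change. Among the measured compounds shown here, the one measured step that bears on it is a 1.4-fold lower number from compound 1 to compound 2 (0.15 log units; within the scatter), on the same side of the molecule, with 4-fluorophenyl in place of 2,4-dihydroxyphenyl on a carbonyl carbon. That exchange alters more of the molecule than the removal of one methoxy, yet it stays within the scatter. It is only indirect evidence, and three compounds support no firm pattern. On that basis, no step beyond the scatter is expected in this assay, and no direction can be assigned. The expected step is a 1.1-fold lower number from compound 3 to compound 4 (0.03 log units; within the scatter). For compound 4 the estimated value is 2.3 ug/mL, with an expected range of 1.3 ug/mL to 3.9 ug/mL.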

Compound 4, half-maximal inhibitory concentration: 2.5 ug/mL
Compound 4: middle estimate off by 1.1-fold (0.04 log units), on the low side, and the stated range covers the measured number.
By their numbers in this assay, from the lowest: compounds 2, 3, 4 and 1 (each within the scatter of the next).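

In this assay, among these compounds, the pair compound 3 and compound 4 isolates hydrogen in place of methoxy on an aromatic carbon, ortho to a hydroxy group, for the first time: a 1.0-fold higher number from compound 3 to compound 4 (0.01 log units; within the scatter). The methoxy is therefore not needed to hold the number at this level in this assay, at least when the hydroxy group stays in place. The exchanges of the other substituents also stay inside the scatter, with hydroxy in place of fluoro (a 1.3-fold higher number from compound 2 to compound 4 (0.11 log units; within the scatter)) and hydrogen in place of hydroxy (a 1.1-fold lower number from compound 1 to compound 4 (0.04 log units; within the scatter)), so none of these single changes separates the compounds, and no measurement at hand offers an explanation for any of these steps.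

All four compounds share the same trimethoxy-substituted part of the core, so the compounds shown say nothing about how much that part contributes to the read-out. From the compounds shown here alone, it also remains open whether a group of another kind at this position, such as an amine, a carboxylic acid or a longer alkoxy chain, would give a step beyond the scatter.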